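A few compounds are considered here, and "the series" means these few. Any claim that something is new, unique, unknown or untested is made for them only; others in the source may bear on it.

Measured compounds:
compound 1, `CC(C(=O)NCc1ccc(C(F)(F)F)cc1N1CCN(C2CCCCC2)CC1)c1ccc(NS(C)(=O)=O)c(F)c1`, which gives 13.8 nM in an assay on CHO cells for antagonist activity at transient receptor potential cation channel subfamily V member 1 (Homo sapiens), read by FLIPR; a lower number here means a stronger inhibitor, a higher number a weaker inhibitor
compound 2, `CC(C(=O)NCc1ccc(C(F)(F)F)cc1SC1CCCC1)c1ccc(NS(C)(=O)=O)c(F)c1`, which gives 0.3 nM in this assay
compound 3, `CC(C(=O)NCc1ccc(C(F)(F)F)cc1SCc1ccco1)c1ccc(NS(C)(=O)=O)c(F)c1`, which gives 3.2 nM in this assay

Compound 3 holds the second highest of the three numbers in this assay; the two steps that lead to it are a 4.3-fold lower number from compound 1 to compound 3 (0.63 log units; beyond the scatter) and an 11-fold higher number from compound 2 to compound 3 (1.03 log units; beyond the scatter). Compound 4, `CC(C(=O)NCc1ccc(C(F)(F)F)cc1-c1ccc(F)c(Cl)c1)c1ccc(NS(C)(=O)=O)c(F)c1`, is not yet measured and differs from compound 3 in one place: 3-chloro-4-fluorophenyl in place of ((furan-2-yl)methyl)sulfanyl on an aromatic carbon. Every measured step in this set changes the group at the same aromatic carbon, so all three bear on this change, though none of them puts a second aromatic ring directly on that carbon. The steps show that the position tolerates wide variation, with a 46-fold lower number from compound 1 to compound 2 (1.66 log units; beyond the scatter) being the largest change seen and the cyclopentylsulfanyl giving the lowest number. Among the measured compounds shown here, with no direct precedent for a 3-chloro-4-fluorophenyl here, the expected step in this assay is uncertain; a move towards a somewhat lower number is thought more likely than a rise, but either could fall within the scatter. Compound 4 is therefore estimated at 2 nM, with a range from 0.3 nM to 12 nM, which corresponds to an expected step of a 1.6-fold lower number from compound 3 to compound 4 (0.20 log units; within the scatter).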

Compound 4, inhibition constant: 0.6 nM
Estimate against measurement, compound 4: 3.3-fold (0.52 log units) above; the measured number falls inside the stated range.
By their numbers in this assay, from the lowest: compounds 2 and 4 (each within the scatter of the next); then compound 3; then compound 1.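

In this assay, among the compounds shown here, a second aromatic ring attached directly to this aromatic carbon proves compatible with a low number, a kind of substituent the earlier compounds did not include: the 3-chloro-4-fluorophenyl gives a 5.3-fold lower number from compound 3 to compound 4 (0.73 log units; beyond the scatter) and a 23-fold lower number from compound 1 to compound 4 (1.36 log units; beyond the scatter) in the two comparisons beyond the scatter. The comparison with the cyclopentylsulfanyl gives a 2.0-fold higher number from compound 2 to compound 4 (0.30 log units; within the scatter) and leaves those two compounds without an order, so a sulfur on this carbon is not required to reach the range of compound 2, and the lowest numbers here are shared by a saturated ring on sulfur and a directly attached halogenated phenyl. Nothing measured here explains these differences between the groups.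

On these data alone, what the chlorine and the fluorine each contribute remains open, as does how an unsubstituted phenyl, a pyridine ring or a phenylsulfanyl would compare at this carbon. Also open, as far as these compounds go, is whether a small amine such as dimethylamino would fall nearer to compound 1 or to compound 2 in this assay on the same shared core.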